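The source may hold more compounds than are shown below. What is called first, only, known or untested is meant among the compounds shown, and "the series" means these compounds.

Of the compounds shown here, three built on one shared core have been tested in a functional assay on HL-60 cells (Homo sapiens) for inhibition; a lower number here means a stronger inhibitor of growth, a higher number a weaker inhibitor of growth. Compound 1 `C=C(C)C(=O)c1ccc(OCc2nc(-c3ccc(C(F)(F)F)cc3)no2)cc1Br` gives 1700 nM. Compound 3 `C=C(C)C(=O)c1ccc(OCc2nc(-c3ccc(C(F)(F)F)cc3)no2)cc1Cl` gives 1900 nM. Compound 2 `C=C(C)C(=O)c1ccc(OCc2nc(C)no2)cc1Cl` gives 9700 nM, the highest number of the three; how its core differs from the core of compound 3 is not broken down here. Compound 1 differs from compound 3 only in one spot, namely (bromo in place of chloro on an aromatic carbon), and that swap produced a 1.1-fold lower number from compound 3 to compound 1 (0.05 log units; within the scatter).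

Compound 4 `C=C(C)C(=O)c1ccc(OCc2nc(C)no2)cc1Br` has not yet been measured. It differs from compound 2 by bromo in place of chloro on an aromatic carbon. For the measured compounds named here, this is the same kind of change as the one from compound 3 to compound 1, though the surroundings are not identical: in compound 3 the changed carbon is meta to a large group, while in compound 2 it is meta to a group of 8 heavy atoms. In this assay the expected step is a 1.1-fold lower number from compound 2 to compound 4 (0.03 log units; within the scatter), because a 1.1-fold lower number from compound 3 to compound 1 (0.05 log units; within the scatter) stayed within the scatter. For compound 4 the estimate in this assay is 9000 nM, with a likely range from 4500 nM to 18000 nM.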

Compound 4, concentration for 50% growth inhibition: 3200 nM
The estimate for compound 4 lay 2.8-fold (0.45 log units) above the measured number, outside the stated range (below it).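

In this assay, bromo in place of chloro on the aromatic carbon gives a 3.0-fold lower number from compound 2 to compound 4 (0.48 log units; beyond the scatter), a step beyond the scatter. Set beside the same swap on the core of compound 3, the size of the step does not carry over: the same change on two cores in this assay, a 1.1-fold lower number (0.05 log units; within the scatter) from compound 3 to compound 1 and a 3.0-fold lower number (0.48 log units; beyond the scatter) from compound 2 to compound 4, 2.7-fold (0.43 log units) apart, beyond the scatter of two such steps

In this series, then, a step read on one core is a poor guide to its size on another, though these two pairs alone set no rule, and they do not show why the cores differ. The compounds shown leave open how other groups on this aromatic carbon, such as fluoro, methoxy or a nitrile, would behave on either core. They also leave open which of the two pairs a further core would follow, for example one with an ethyl group or an amine in place of the part that separates compound 2 from compound 3.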